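Replacing the pyrazole of compound 2 with an oxazole

The source may hold more compounds than are shown below. What is called first, only, known or untested is meant among the compounds shown, and "the series" means these compounds.

In a functional assay on CHO cells for agonist activity at Alpha-1B adrenergic receptor (Homo sapiens), read by FLIPR and calcium flux (a higher number here means that more compound is needed for the effect, a lower number that less compound is needed), compound 2 `c1cc(-c2ccn[nH]2)c2c(c1)C(c1ncc[nH]1)CC2` gives 600 nM, the lowest of the two numbers in the series. Compound 1 `Cc1n[nH]cc1-c1cccc2c1CCC2c1ncc[nH]1` gives 902 nM, a step of a 1.5-fold lower number from compound 1 to compound 2 (0.18 log units; within the scatter). Compound 3 `Cc1oncc1-c1cccc2c1CCC2c1ncc[nH]1` gives only a limit, > 10000 nM, as noted for (the limit of > 10000 nM in this assay, at which 1 of the 3 values shown sits). The step from compound 2 to compound 3 is an at least 16-fold higher number from compound 2 to compound 3 (1.22 log units; beyond the scatter), and from compound 1 to compound 3 it is an at least 11-fold higher number from compound 1 to compound 3 (1.04 log units; beyond the scatter). Compound 4 `c1cc(-c2ncco2)c2c(c1)C(c1ncc[nH]1)CC2` differs from compound 2 by 1,3-oxazol-2-yl in place of 1H-pyrazol-5-yl on an aromatic carbon. The measured steps that swap out the 1H-pyrazol-5-yl or 3-methyl-1H-pyrazol-4-yl for an oxazole were large losses, so a similarly large step upward is expected, with a real chance of a limit. The expected step from compound 2 to compound 4 is a 13-fold higher number from compound 2 to compound 4 (1.12 log units; beyond the scatter); compound 4 is estimated at 8000 nM, ranging from 2000 nM to 30000 nM.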

Compound 4, half-maximal effective concentration: > 10000 nM
Compound 4 gave a limit, no number; the forecaster's own chance of this, stated with the estimate: 45%; middle value at least 1.2-fold (0.09 log units) away from the limit.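

In this assay, the large loss seen with 5-methyl-1,2-oxazol-4-yl recurs with 1,3-oxazol-2-yl, so among the compounds shown it is not confined to one oxazole arrangement: an at least 16-fold higher number from compound 2 to compound 4 (1.22 log units; beyond the scatter), and an at least 11-fold higher number from compound 1 to compound 4 (1.04 log units; beyond the scatter). Compound 3 and compound 4 are both limits, so the step between them cannot be read and the two oxazoles remain unranked: the limit of > 10000 nM in this assay, at which 2 of the 4 values shown sit.

1,3-oxazol-2-yl enters with 0 hydrogen-bond donors where 1H-pyrazol-5-yl has 1, but this swap alone cannot isolate the donor's contribution. On these data alone, whether an amine or an amide on this aromatic carbon would keep the response remains open.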